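The source may report more compounds than this note shows. Statements on the series, on what has been measured and on what is new or still open speak of the compounds shown alone.

Series notes. Compound 2 `CS(=O)(=O)Oc1cc(-c2ccccc2)nc2ccccc12` gives 6.04 ug/mL in a functional assay on L1210 (1565) cells (Mus musculus) for cytotoxicity; on this read-out higher numbers stand for an effect only at larger amounts of compound and lower numbers for an effect already at smaller amounts. Compound 3 `COc1ccc2nc(-c3ccccc3)cc(O)c2c1` gives 0.06 ug/mL in this assay, so of the two numbers measured compound 2 holds the higher one, and the gap down to compound 3 lies beyond the scatter. Compound 1 `Oc1cc(-c2ccccc2)nc2c(O)cccc12` reaches only a limit in this assay, > 10 ug/mL; (the limit of > 10 ug/mL in this assay, at which 1 of the 3 values shown sits). Compound 4 `CCCOc1cc(-c2ccccc2)nc2ccccc12` is not yet measured. It differs from compound 2 in one place: propyl in place of methylsulfonyl on an oxygen on an aromatic ring. Among the compounds with values here, no measured pair shows this change, so its size is unknown. A modest step downward, or none beyond the scatter, is expected for compound 4, as a 2.0-fold lower number from compound 2 to compound 4 (0.30 log units; within the scatter). Compound 4 is expected to give about 3 ug/mL in this assay, within 0.6 ug/mL to 15 ug/mL.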

Compound 4, half-maximal effective concentration: > 10 ug/mL
Compound 4 gave a limit, no number; the forecaster's own chance of this, stated with the estimate: 20%; at least 3.3-fold (0.52 log units) between middle value and limit.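

Within the data shown here, the step with propyl in place of methylsulfonyl on an oxygen on an aromatic ring is the first one read at this position: an at least 1.6-fold higher number from compound 2 to compound 4 (0.21 log units; that floor lies within the scatter). The swap therefore brings no drop in the number, though its floor alone does not establish a real rise. The result for compound 4 in this assay is a limit, not a number, so the true size of the change stays unread: the limit of > 10 ug/mL in this assay, at which 2 of the 4 values shown sit.

On these data alone, whether the loss of the methylsulfonyl group or the arrival of propyl sets this outcome remains open. So does the effect of an amine-bearing chain or a longer carbon chain on that oxygen.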